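Tert-Butyl for Methyl on a Pair with Level Inhibition

The compounds below may be only part of what the source reports. "The series", "measured", "known", "first", "only" and "open" are said of these compounds alone.

Compound 1 `COc1ccc(-c2cc3c(c(N)nn3C)c(=O)[nH]2)cc1`: -8%
Compound 2 `Cc1cc2nn(-c3ccccc3)c(N)c2c(=O)[nH]1`: 1%

In an assay on isolated protein for inhibition of RAC-beta serine/threonine-protein kinase (Homo sapiens), read by mobility shift assay, tested at 30 uM (on this read-out lower numbers stand for less inhibition and higher numbers for more inhibition at the one concentration tested (going by the name of the read-out)), compound 1 gives -8%, and compound 2 gives 1%. Compound 2 stands alongside compound 1, the gap between them within the scatter, so the inhibition in this assay is level between them. Compound 3 `CC(C)(C)c1cc2nn(-c3ccccc3)c(N)c2c(=O)[nH]1` has not yet been measured in this assay. Its change from compound 2 is tert-butyl in place of methyl on an aromatic carbon. Within the data shown here, no measured step is known for this change, and the step of a number 1 percentage points higher from compound 2 to compound 3 (within the scatter) is expected to stay within the scatter. Compound 3 is therefore estimated at 2%, with a range from -10% to 15%.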

Compound 3, a percentage reported as inhibition, at one concentration (the size of the read-out at that concentration, not a potency): 3%
Beside the measured number, compound 3's estimate is 1 percentage points below it, and the stated range covers the measured number.
By their numbers in this assay, from the lowest: compounds 1, 2 and 3 (each within the scatter of the next, the first and the last beyond it).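

In this assay, a number 2 percentage points higher from compound 2 to compound 3 (within the scatter) shows that this aromatic carbon next to the ring nitrogen takes tert-butyl in place of methyl, going from 1 heavy atom to 4 heavy atoms, with the inhibition level. Compound 1 and compound 2 differ in more than one place, so they could not show this for the position alone. Nothing measured here gives a reason for this level result. The compounds shown leave open whether an amine or a carboxylic acid on this carbon would move the inhibition beyond the scatter.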